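Cytotoxicity of bicyclic amines with a small heteroaryl arm

A few compounds are considered here, and "the series" means these few. Any claim that something is new, unique, unknown or untested is made for them only; others in the source may bear on it.

The series shares one saturated bicyclic core carrying an amine, to which a heteroaryl-methyl arm is attached. Compound 1 is `C[C@H]1[C@H](NCc2cncs2)C[C@H]2C[C@@H]1C2(C)C`. In an ADME assay on MDCK cells (Canis lupus familiaris) for cytotoxicity, read by microscopy, with a stated time of 48 h (a lower number here means that less compound is tolerated, a higher number that more compound is tolerated), compound 1 reaches only the limit of the measurement, > 100000 nM, so no number is known for it. The evidence from this assay is the limit of > 100000 nM in this assay, at which 1 of the 2 values shown sits. The second measured compound, compound 2, is `C[C@H]1[C@H](NCc2sccc2C2CCCC2)C[C@H]2C[C@@H]1C2(C)C`; in this assay compound 2 gives 12500 nM. The unmeasured compound 3 is `C[C@H]1[C@H](NCc2cncnc2)C[C@H]2C[C@@H]1C2(C)C`. It differs from compound 1 by pyrimidin-5-yl in place of 1,3-thiazol-5-yl on a saturated chain carbon bound to an amine nitrogen. For the measured compounds named here, no measured pair shares this change, so the step from compound 1 to compound 3 is expected to stay within the scatter, with compound 3 most likely again sitting at the limit. He expects compound 3 to show about 100000 nM, between 25000 nM and 200000 nM, which means a step of a number no higher from compound 1 to compound 3 (the limit leaves the size open).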

Compound 3, minimum cytotoxic concentration: > 100000 nM
Compound 3 ended at the assay's limit; the forecaster's own chance of this, stated with the estimate: 65%; the middle value lies on the limit itself.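

In this assay, for the compounds shown here, compound 1 and compound 3 both stand at the limit of the measurement, and no step between them can be read. The compounds shown leave open whether pyrimidin-5-yl in place of 1,3-thiazol-5-yl changes the minimum cytotoxic concentration at all, and in which direction.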